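Piperidine amide in place of the glycine-derived amide

This account rests on a few compounds, and the source may have more. Where it says the series, first, only, none or still open, it means among the compounds named here.

Of the two compounds measured in an assay on CHO cells for inhibition of bone morphogenetic protein 1 (Homo sapiens), read by fluorescence (on this read-out higher numbers stand for weaker inhibition and lower numbers for stronger inhibition), compound 2 `O=C(O)CNC(=O)c1noc([C@H](CCCC2CCCCC2)CC(=O)NO)n1` has the lowest number: compound 2 gives 21 nM, whereas compound 1 `O=C(C[C@@H](CCCC1CCCCC1)c1nc(C(=O)NCc2ccccc2)no1)NO` gives 57 nM. Among the measured compounds shown here, the only recorded step, a 2.7-fold lower number from compound 1 to compound 2 (0.43 log units; beyond the scatter), exchanges a phenyl for a carboxy on the chain carbon bound to the amide-type nitrogen.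

Compound 3 `O=C(C[C@@H](CCCC1CCCCC1)c1nc(C(=O)N2CCCCC2)no1)NO` departs from compound 2 differently: piperidin-1-yl in place of (carboxymethyl)amino on a carbonyl carbon. This removes the amide hydrogen together with the carboxy end, so the measured step does not map onto it directly; it only shows that the amide substituent can shift the number by a modest amount. For the measured compounds named here, compound 3 is therefore expected to land near the two known numbers, with a slight worsening as the more likely direction, a step of a 2.4-fold higher number from compound 2 to compound 3 (0.38 log units; beyond the scatter), giving an estimated value of 50 nM within a range of 15 nM to 170 nM.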

Compound 3, half-maximal inhibitory concentration: 26 nM
Compound 3: middle estimate off by 1.9-fold (0.28 log units), on the high side; low and high end bracket the measured number.
By their numbers in this assay, from the lowest: compounds 2 and 3 (each within the scatter of the next); then compound 1.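

In this assay, piperidin-1-yl in place of (carboxymethyl)amino on this carbonyl carbon gives a 1.2-fold higher number from compound 2 to compound 3 (0.09 log units; within the scatter) so, among these compounds, the carboxy end and the amide hydrogen of compound 2 are not needed for a number in this range. Piperidin-1-yl in place of benzylamino gives a 2.2-fold lower number from compound 1 to compound 3 (0.34 log units; beyond the scatter) and this modest step, together with the earlier one, leaves compound 1 with the highest number of the three. Nothing measured here explains why these groups give these numbers.

From the compounds shown here alone, whether the six-membered ring itself matters remains open, as a smaller pyrrolidin-1-yl or an open-chain dimethylamino group on the same carbonyl carbon would test that. A morpholin-4-yl group would show whether an oxygen atom in the ring changes the number.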